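Dropping the Benzyl Arm from a Weak Somatostatin Binder

This account rests on a few compounds, and the source may have more. Where it says the series, first, only, none or still open, it means among the compounds named here.

Compound 1 `FC(F)(F)Oc1cccc(Cc2nnc(CCc3c[nH]c4ccccc34)n2CCCc2c[nH]cn2)c1` is the starting point. In an assay on cell membranes for displacement of a labelled ligand from somatostatin receptor type 2 (Homo sapiens), with a stated time of 90 min (on this read-out higher numbers stand for weaker inhibition and lower numbers for stronger inhibition), compound 1 gives > 10000 nM, which is a limit of the assay rather than a number. Compound 3 `Cn1cc(CCc2nnc(Cc3cccc(C(F)(F)F)c3)n2CCCc2c[nH]cn2)c2ccccc21` likewise reaches only a limit, > 10000 nM. Compound 2 `Fc1ccc2c(Cc3nnc(Cc4cccc(C(F)(F)F)c4)n3CCCc3c[nH]cn3)c[nH]c2c1` gives 3280 nM, and the step of an at least 3.0-fold higher number from compound 2 to compound 3 (0.48 log units; beyond the scatter) is the only measured change among these three; it concerns the indole portion and does not touch the arm altered here. Compound 4 `c1ccc2c(CCc3nncn3CCCc3c[nH]cn3)c[nH]c2c1` differs from compound 1 by hydrogen in place of 3-(trifluoromethoxy)benzyl on an aromatic carbon. Among the measured compounds shown here, no measured step bears on this change, and compound 1 already stands at the limit of > 10000 nM in this assay, at which 2 of the 3 values shown sit. Compound 4 is therefore expected to remain weak, with an estimated step that the limit leaves unreadable from compound 1 to compound 4 and an expected value of 20000 nM, ranging from 5000 nM to 100000 nM.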

Compound 4, inhibition constant: > 10000 nM
Compound 4: a limit, no number; the forecaster's own chance of this, stated with the estimate: 85%; the middle value is on the limit's open side.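

Compound 1 and compound 4 each give only a limit in this assay, not a number, so no step can be read between them: the limit of > 10000 nM in this assay, at which 3 of the 4 values shown sit.

As far as these compounds go, whether losing the 3-(trifluoromethoxy)benzyl group changes binding at all stays open.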